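The source may hold more compounds than are shown below. What is called first, only, known or untested is meant among the compounds shown, and "the series" means these compounds.

Compound 1 `COc1ccc(S(=O)(=O)Nc2ccc(C(=O)CSC(C)=O)cn2)cc1`: 540 nM
Compound 2 `CC(=O)SCC(=O)c1ccc(NS(=O)(=O)c2ccc(OCCCN3CCCCC3)cc2)nc1`: 1000 nM

In a functional assay on HCT-116 cells (Homo sapiens) for cytotoxicity (on this read-out higher numbers stand for an effect only at larger amounts of compound and lower numbers for an effect already at smaller amounts), compound 1 holds the lower of the two numbers, and compound 2 sits within the scatter of it. Compound 3 `CC(=O)SCC(=O)c1ccc(NS(=O)(=O)c2ccc(OCCc3ccccn3)cc2)nc1` differs from compound 1 in one place: (pyridin-2-yl)methyl in place of hydrogen on a saturated chain carbon bound to an oxygen on an aromatic ring. Among the measured compounds shown here, the one measured step that bears on this change is a 1.9-fold higher number from compound 1 to compound 2 (0.27 log units; within the scatter), where a different group entered at the same place on the saturated chain carbon bound to an oxygen on an aromatic ring. No shift beyond the scatter is therefore expected in this assay. Compound 3 is estimated at 750 nM, with a range from 350 nM to 1600 nM. The expected step, a 1.4-fold higher number from compound 1 to compound 3 (0.14 log units; within the scatter), stays within the scatter.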

Compound 3, half-maximal effective concentration: 750 nM
Beside the measured number, compound 3's estimate shows no gap at the digits printed; low and high end bracket the measured number.
By their numbers in this assay, from the lowest: compounds 1, 3 and 2 (each within the scatter of the next).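

In this assay, the pyridin-2-yl chain end gives a 1.4-fold higher number from compound 1 to compound 3 (0.14 log units; within the scatter), and exchanging the chain end of compound 2 for it gives a 1.3-fold lower number from compound 2 to compound 3 (0.12 log units; within the scatter). This position thus carries a second, aromatic chain end as well as the saturated piperidin-1-yl one, with every step within the scatter. Nothing available explains why these numbers stay so close. From the compounds shown here alone, whether a carboxylic acid or a morpholin-4-yl group at the end of the chain would move the number beyond the scatter remains open.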